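Bromo for chloro on the indole of compound 3

A few compounds are considered here, and "the series" means these few. Any claim that something is new, unique, unknown or untested is made for them only; others in the source may bear on it.

In a functional assay on HL-60 cells (Homo sapiens) for antiproliferative activity, read by CellTiter-Glo, with a stated time of 72 h (a lower number here means a stronger inhibitor, a higher number a weaker inhibitor), compound 1 `CO[C@@H]1[C@H](N(C)c2ncc(-c3c[nH]c4ccc(Br)cc34)s2)C[C@H]2O[C@]1(C)n1c3ccccc3c3c4c(c5c6ccccc6n2c5c31)C(=O)NC4` returns only a limit, > 10000 nM. Compound 2 `CO[C@@H]1[C@H](N(C)c2ncc(-c3c[nH]c4ccccc34)s2)C[C@H]2O[C@]1(C)n1c3ccccc3c3c4c(c5c6cc(Cl)ccc6n2c5c31)C(=O)NC4` likewise returns only a limit in this assay, > 10000 nM. Compound 3 `CO[C@@H]1[C@H](N(C)c2ncc(-c3c[nH]c4ccc(Cl)cc34)s2)C[C@H]2O[C@]1(C)n1c3ccccc3c3c4c(c5c6cc(Cl)ccc6n2c5c31)C(=O)NC4` also returns only a limit in this assay, > 10000 nM. For the measured compounds named here, compound 3 therefore stands where every measured member of the series stands, and the one single-point step, a step that the two limits leave unreadable from compound 2 to compound 3, cannot be sized because of the limit of > 10000 nM in this assay, at which 3 of the 3 values shown sit.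

Compound 4 `CO[C@@H]1[C@H](N(C)c2ncc(-c3c[nH]c4ccc(Br)cc34)s2)C[C@H]2O[C@]1(C)n1c3ccccc3c3c4c(c5c6cc(Cl)ccc6n2c5c31)C(=O)NC4` differs from compound 3 by bromo in place of chloro on an aromatic carbon. Going by the values given here, no measured step exchanges bromo for chloro; the only measured step, a step that the two limits leave unreadable from compound 2 to compound 3, concerns chloro entering elsewhere and is itself unreadable. Compound 1, which carries the bromo indole on a core without the added chloro, sits at the same limit as compound 3, so the series offers no sign of a readable change in this assay.

The step that the limit leaves unreadable from compound 3 to compound 4 is therefore expected to be none beyond the scatter. Compound 4 is expected to give 20000 nM in this assay, with a range from 8000 nM to 60000 nM, most likely reported as a limit again.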

Compound 4, half-maximal inhibitory concentration: > 10000 nM
Compound 4: a limit, no number (the forecaster's own chance of this, stated with the estimate: 85%); the middle value does not contradict the limit.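

No new step can be read in this assay between compound 4 and compound 1, compound 2 or compound 3, because every value is a limit: the limit of > 10000 nM in this assay, at which 4 of the 4 values shown sit.

The compounds shown leave open whether bromo, chloro or hydrogen at these places makes any difference in this assay.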